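Phenyl for pyridinyl on a shared core: a near neighbour

The compounds below may be only part of what the source reports. "The series", "measured", "known", "first", "only" and "open" are said of these compounds alone.

The series is assessed in a functional assay on HCT-15 cells (Homo sapiens) for cytotoxicity, read by CCK-8 assay and cell counting, with a stated time of 2 days; on this read-out higher numbers stand for weaker inhibition and lower numbers for stronger inhibition. Compound 1 `Oc1cccc(-c2cc(-c3cccnc3)nc(-c3cccc(Cl)c3)c2)c1` carries a hydroxyphenyl group, a pyridin-3-yl group and a 3-chlorophenyl group on a shared core, but in this assay compound 1 gives "not determined" (no result reported), so no single number places it. Its two measured relatives give an idea of the level this family reaches. Compound 2 `Oc1cccc(-c2cc(-c3ccc(Cl)cc3)nc(-c3cccnc3)c2)c1` gives 16800 nM in this assay. Compound 3 `Oc1ccc(-c2cc(-c3cccnc3)nc(-c3cccc(Cl)c3)c2)cc1` gives 21300 nM in this assay, and these two values lie within the usual scatter of each other, so no order between them can be drawn.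

Compound 4 `Oc1cccc(-c2cc(-c3ccccc3)nc(-c3cccc(Cl)c3)c2)c1` differs from compound 1 in one place: phenyl in place of pyridin-3-yl on an aromatic carbon, next to the ring nitrogen of the shared core. Among the compounds with values here, with no measured pair to show what this change does, the account can only note that the two measured relatives sit close together. The step from compound 1 to compound 4 in this assay is expected to be none beyond the scatter, with no direction favoured.

Compound 4 is therefore estimated at 18000 nM in this assay, with a range from 6000 nM to 55000 nM.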

Compound 4, half-maximal inhibitory concentration: 2550 nM
Compound 4: the middle estimate sits 7.1-fold (0.85 log units) above what was measured; the measured number lies below the stated range.
By their numbers in this assay, from the lowest: compound 4; then compounds 2 and 3 (each within the scatter of the next).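

Within the data shown here, compound 4 has no partner with a single number that differs from it in one place, so no step from compound 1 to compound 4 can be read in this assay. The compounds shown leave open what phenyl in place of pyridin-3-yl does on the shared core. No supporting data bear on this result.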